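The compounds below may be only part of what the source reports. "The series", "measured", "known", "first", "only" and "open" are said of these compounds alone.

Measured compounds:
compound 1 `Cc1cc(OC(=O)CCCCCO[N+](=O)[O-])n(-c2ccccc2)n1`: < 0.0167 h
compound 2 `Cc1cc(OC(=O)CCCC(CO[N+](=O)[O-])O[N+](=O)[O-])n(-c2ccccc2)n1`: < 0.0167 h
compound 3 `Cc1cc(OC(=O)c2ccc(OCC(CO[N+](=O)[O-])O[N+](=O)[O-])cc2)n(-c2ccccc2)n1`: < 0.0167 h

Three esters of a shared core were tested in an ADME assay on liver (Rattus norvegicus, strain Wistar) for metabolic stability, read by HPLC, tested at 200 uM; a lower number here means that the compound disappears faster, a higher number that the compound lasts longer. In this assay compound 1 gives < 0.0167 h, which is a limit of the assay and not a number. Compound 2 likewise gives < 0.0167 h, again a limit. Compound 3 gives < 0.0167 h, also a limit. All three therefore share (the limit of < 0.0167 h in this assay, at which 3 of the 3 values shown sit).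

Compound 2 and compound 1 differ by hydrogen in place of nitrooxy on a saturated chain carbon bound to two saturated chain carbons. The step that the two limits leave unreadable from compound 2 to compound 1 is unreadable because both compounds sit at the limit of < 0.0167 h in this assay, at which 3 of the 3 values shown sit. How the core of compound 3 differs from that of compound 2 is not broken down here.

Compound 4 `Cc1cc(OC(=O)c2ccc(OCCCO[N+](=O)[O-])cc2)n(-c2ccccc2)n1` is not yet measured. It differs from compound 3 by hydrogen in place of nitrooxy on a saturated chain carbon bound to two saturated chain carbons, the same change as that from compound 2 to compound 1, at the same place. Since compound 3 already sits at the limit of < 0.0167 h in this assay, at which 3 of the 3 values shown sit, and the earlier step gave no readable size, compound 4 is expected to give 0.01 h, somewhere between 0.003 h and 0.03 h. The step this estimate means is a step that the limit leaves unreadable from compound 3 to compound 4, and it is expected to be unreadable again, most likely as another limit.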

Compound 4, half-life in the liver assay: < 0.0167 h
Compound 4 gave a limit, no number (the forecaster's own chance of this, stated with the estimate: 85%); the middle value lies beyond the limit too.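

In the liver assay compound 3 gives < 0.0167 h, which is a limit and not a number. In the liver assay compound 4 gives < 0.0167 h, which is also a limit and not a number. No step can be read between these two compounds: the limit of < 0.0167 h in the liver assay, at which 4 of the 4 values shown sit. The compounds shown leave open how long any of these esters lasts in the liver assay, and whether hydrogen in place of nitrooxy changes that half-life at all. In a physicochemical assay for metabolic stability, read by HPLC (a lower number here means that the compound disappears faster, a higher number that the compound lasts longer), compound 3 gives 25 h and compound 4 gives 35 h. This is, in the physicochemical assay, a 1.4-fold higher number from compound 3 to compound 4 (0.15 log units; within the scatter).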